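The compounds below may be only part of what the source reports. "The series", "measured", "known", "first", "only" and "open" are said of these compounds alone.

Of the compounds shown here, three have been tested in a functional assay on CCRF-CEM cells (Homo sapiens); on this read-out higher numbers stand for lower toxicity in this test and lower numbers for higher toxicity in this test. Compound 1, `Cc1cn([C@@H]2O[C@@H]3COC4(O)CS(=O)(=O)O[C@@]34[C@H]2O[Si](C)(C)C(C)(C)C)c(=O)[nH]c1=O`, gives 100000 nM in this assay. Compound 2, `CCOC(=O)CNC(=O)NC1=CS(=O)(=O)O[C@@]12[C@@H](CO[Si](C)(C)C(C)(C)C)O[C@@H](n1cc(C)c(=O)n(C)c1=O)[C@@H]2O[Si](C)(C)C(C)(C)C`, gives 5020 nM, the lowest of the three numbers, and compound 3, `COC(=O)NC1=CS(=O)(=O)O[C@@]12[C@@H](CO[Si](C)(C)C(C)(C)C)O[C@@H](n1cc(C)c(=O)n(C)c1=O)[C@@H]2O[Si](C)(C)C(C)(C)C`, gives 30700 nM. Among the measured compounds shown here, compound 2 thus stands furthest toward the toxic end of the range seen, and the step of a 6.1-fold higher number from compound 2 to compound 3 (0.79 log units; beyond the scatter) is the only one among the measured compounds that changes a single place.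

Compound 4, `Cc1cn([C@@H]2O[C@H](CO[Si](C)(C)C(C)(C)C)[C@@]3(OS(=O)(=O)C=C3NCC(=O)C(=O)O)[C@H]2O[Si](C)(C)C(C)(C)C)c(=O)n(C)c1=O`, differs from compound 2 by (carboxycarbonyl)methyl in place of ((ethoxycarbonyl)methyl)carbamoyl on an amine nitrogen. For the measured compounds named here, no measured step covers exactly this change. Going by the values given here, the closest precedent is the exchange of the same side chain in the step of a 6.1-fold higher number from compound 2 to compound 3 (0.79 log units; beyond the scatter), which moved the number away from compound 2 and out of the scatter. On that basis a step in the same direction, of at least that size, is expected for compound 4, giving an 8.0-fold higher number from compound 2 to compound 4 (0.90 log units; beyond the scatter). Compound 4 is therefore estimated at 40000 nM, with a likely range from 10000 nM to 100000 nM, the measurement itself still being awaited.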

Compound 4, half-maximal cytotoxic concentration: 72600 nM
The estimate for compound 4 lay 1.8-fold (0.26 log units) below the measured number; the measured number falls inside the stated range.
By their numbers in this assay, from the lowest: compound 2; then compound 3; then compounds 4 and 1 (each within the scatter of the next).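

In this assay, a second replacement on this amine nitrogen, (carboxycarbonyl)methyl for ((ethoxycarbonyl)methyl)carbamoyl, also raises the number, with a 14-fold higher number from compound 2 to compound 4 (1.16 log units; beyond the scatter) as the step, so compound 2 now stands lowest against two different replacements rather than one. The two replacements also do not read alike, since a 2.4-fold higher number from compound 3 to compound 4 (0.37 log units; beyond the scatter) marks a modest separation between methoxycarbonyl and (carboxycarbonyl)methyl on the same nitrogen. Nothing available here explains why these groups differ. As far as these compounds go, the change from compound 2 to compound 4 alters the whole side chain, so it remains open which part of ((ethoxycarbonyl)methyl)carbamoyl goes with the low number of compound 2. A carboxylic acid in place of the ethyl ester on the same carbamoyl chain, or a longer chain between the carbamoyl and the ester, would help separate those parts.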